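Benzhydryl to Benzyl Ester: Expecting the Next Step

The compounds below may be only part of what the source reports. "The series", "measured", "known", "first", "only" and "open" are said of these compounds alone.

Compound 1, `CC1(C)S[C@@H]2/C(=C\C(=O)c3ccc(C(F)(F)F)cc3)C(=O)N2[C@H]1C(=O)OC(c1ccccc1)c1ccccc1`: 26700 nM
Compound 2, `CC1(C)S[C@@H]2/C(=C\C(=O)OC(c3ccccc3)c3ccccc3)C(=O)N2[C@H]1C(=O)OC(c1ccccc1)c1ccccc1`: 9100 nM

Both compounds were tested in a functional assay on A-375 cells (Homo sapiens) for cytotoxicity, read by MTT assay, with a stated time of 48 h; on this read-out lower numbers stand for stronger inhibition and higher numbers for weaker inhibition. Compound 2 stands at the lowest of the two numbers, and compound 1 gives the higher one; the gap between them lies beyond the scatter of this assay. For the measured compounds named here, no single-change step between measured compounds is available to guide the next comparison.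

Compound 3, `CC1(C)S[C@@H]2/C(=C\C(=O)OCc3ccccc3)C(=O)N2[C@H]1C(=O)OC(c1ccccc1)c1ccccc1`, differs from compound 2 in one place: hydrogen in place of phenyl on a saturated chain carbon bound to an aromatic carbon and an oxygen next to a carbonyl group. Going by the values given here, with no measured step of this kind, the expectation rests on compound 2 alone. The change is expected to produce a modest step toward a higher number in this assay, one that may well not exceed the scatter. Compound 3 is therefore estimated at 15000 nM, with a range from 5000 nM to 45000 nM. This estimate corresponds to an expected step of a 1.6-fold higher number from compound 2 to compound 3 (0.22 log units; within the scatter).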

Compound 3, half-maximal inhibitory concentration: 7100 nM
Beside the measured number, compound 3's estimate is 2.1-fold (0.32 log units) above it; the measured number falls inside the stated range.
By their numbers in this assay, from the lowest: compounds 3 and 2 (each within the scatter of the next); then compound 1.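

In this assay, hydrogen in place of phenyl on this saturated chain carbon gives a 1.3-fold lower number from compound 2 to compound 3 (0.11 log units; within the scatter), so the second phenyl can go without a change that this assay can distinguish. For the compounds shown here, compound 3 also supplies the first one-place comparison at the carbonyl carbon: benzyloxy in place of 4-(trifluoromethyl)phenyl gives a 3.8-fold lower number from compound 1 to compound 3 (0.58 log units; beyond the scatter), a modest step that lies beyond the scatter. Nothing available explains either step.

The compounds shown leave open whether the single phenyl of the benzyloxy group is itself needed, since no group without an aromatic ring stands at this place. Going by these compounds, it also remains open how a carboxylic acid, an amine or a longer chain in place of the benzyloxy group would read in this assay.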